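Bromo Core Joined to the Chloromethoxyphenylethyl Arm

The source may hold more compounds than are shown below. What is called first, only, known or untested is meant among the compounds shown, and "the series" means these compounds.

Compound 3 `CN(C)c1ccc(CN(Cc2ccc(C(C)(C)C)cc2)Cc2cc3cc(Br)ccc3[nH]c2=O)cc1` was tested in a toxicity assay on MDCK cells (Canis lupus familiaris) for cytotoxicity, read by crystal violet staining, with a stated time of 48 h; on this read-out higher numbers stand for lower toxicity in this test and lower numbers for higher toxicity in this test. In this assay compound 3 gives > 10000 nM, which is a limit of the assay rather than a number. Two further compounds with the same arrangement around the amine nitrogen stand in the same place. Compound 1 `COc1ccc(C(C)N(Cc2ccc(C(C)(C)C)cc2)Cc2cc3cc(C)ccc3[nH]c2=O)cc1Cl` gives > 10000 nM in this assay, again a limit. Compound 2 `CCc1ccc2[nH]c(=O)c(CN(Cc3ccc(C(C)(C)C)cc3)C(C)c3ccc(OC)c(Cl)c3)cc2c1` gives > 10000 nM in this assay, also a limit. For the measured compounds named here, the only step measured between compounds that differ in one place, a step that the two limits leave unreadable from compound 1 to compound 2, is therefore unreadable. What the numbers show is summed up by the limit of > 10000 nM in this assay, at which 3 of the 3 values shown sit.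

Compound 4 `COc1ccc(C(C)N(Cc2ccc(C(C)(C)C)cc2)Cc2cc3cc(Br)ccc3[nH]c2=O)cc1Cl` differs from compound 3 in one place: 1-(3-chloro-4-methoxyphenyl)ethyl in place of 4-(dimethylamino)benzyl on an amine nitrogen. Compound 4 thus carries the same 1-(3-chloro-4-methoxyphenyl)ethyl group on the amine nitrogen as compounds 1 and 2, while keeping the core of compound 3. Going by the values given here, no measured step bears directly on this change, and every compound shown sits at the limit, so no step of readable size or direction in this assay can be drawn from them. Compound 4 is therefore expected to sit at the limit as well, with an estimate of 15000 nM, between 8000 nM and 40000 nM. The step that the limit leaves unreadable from compound 3 to compound 4 is expected to be none beyond the scatter.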

Compound 4, half-maximal cytotoxic concentration: > 10000 nM
Compound 4 gave a limit, no number (the forecaster's own chance of this, stated with the estimate: 85%); the middle value does not contradict the limit.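

No step from compound 1, compound 2 or compound 3 to compound 4 can be read in this assay, since each of these compounds gives a limit of the assay and not a number: the limit of > 10000 nM in this assay, at which 4 of the 4 values shown sit.

The compounds shown leave open whether the bromo, methyl and ethyl groups on the core, or the two groups on the amine nitrogen, differ at all in this assay.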